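Amide substituent changes on a stilbene-cinnamamide series

The source may report more compounds than this note shows. Statements on the series, on what has been measured and on what is new or still open speak of the compounds shown alone.

Among the measured compounds shown here, compound 3 `CCCCNC(=O)/C=C/c1c(/C=C/c2ccc(OC)cc2)cc(OC)cc1OC` stands lowest of the three numbers so far in a functional assay on A549 cells (Homo sapiens) for inhibition, read by MTT assay, with a stated time of 48 h (a lower number here means a stronger inhibitor, a higher number a weaker inhibitor), where compound 3 gives 1880 nM. Compound 1 `CCNC(=O)/C=C/c1c(/C=C/c2ccc(OC)cc2)cc(OC)cc1OC` gives 7860 nM and compound 2 `CCCCCCCCNC(=O)/C=C/c1c(/C=C/c2ccc(OC)cc2)cc(OC)cc1OC` gives 8660 nM; the steps of a 4.2-fold lower number from compound 1 to compound 3 (0.62 log units; beyond the scatter) and a 4.6-fold lower number from compound 2 to compound 3 (0.66 log units; beyond the scatter) both lie beyond the scatter, while a 1.1-fold higher number from compound 1 to compound 2 (0.04 log units; within the scatter) lies within it.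

Compound 4 `COc1ccc(/C=C/c2cc(OC)cc(OC)c2/C=C/C(=O)Nc2cc(OC)c(OC)c(OC)c2)cc1` is not yet measured. The change is 3,4,5-trimethoxyphenyl in place of butyl on an amide-type nitrogen. For the measured compounds named here, none of the measured steps concerns an aromatic group on the amide nitrogen; the steps seen only compare chain lengths, where ethyl and octyl are both weaker than butyl and the two longer chains sit together. That gives no direct guide to an aryl amide. The expectation is therefore a modest loss relative to compound 3, with wide uncertainty, a 1.6-fold higher number from compound 3 to compound 4 (0.20 log units; within the scatter), because the only bearing data are a 4.6-fold lower number from compound 2 to compound 3 (0.66 log units; beyond the scatter) showing that departure from butyl cost activity. For compound 4 the estimate in this assay is 3000 nM, within 600 nM to 15000 nM.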

Compound 4, half-maximal inhibitory concentration: 5140 nM
The estimate for compound 4 lay 1.7-fold (0.23 log units) below the measured number, and the stated range covers the measured number.
By their numbers in this assay, from the lowest: compound 3; then compounds 4, 1 and 2 (each within the scatter of the next).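

In this assay, an aromatic group on the amide-type nitrogen now enters the comparison: 3,4,5-trimethoxyphenyl in place of butyl gives a 2.7-fold higher number from compound 3 to compound 4 (0.44 log units; beyond the scatter), so this position does not accept the ring as well as it accepts butyl. Against the other two chains the same group is not separated, with a 1.7-fold lower number from compound 2 to compound 4 (0.23 log units; within the scatter) and a 1.5-fold lower number from compound 1 to compound 4 (0.18 log units; within the scatter), so among the four groups at this position butyl alone stands apart, while the aryl amide sits with the ethyl and octyl amides.

Still open, going by these compounds, is whether the loss from butyl depends on the three methoxy groups, which an unsubstituted phenyl or a benzyl on this nitrogen would show, and whether propyl or pentyl chains match butyl. No measured evidence on these compounds gives a reason for any of these steps.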